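The compounds below may be only part of what the source reports. "The series", "measured", "known", "first", "only" and "open" are said of these compounds alone.

Compound 1 `NC(=O)c1c(NC(=O)c2ccccc2Cl)sc2c1CCN(Cc1ccccc1F)C2` — 12900 nM
Compound 2 `NC(=O)c1c(NC(=O)c2ccc(C(F)(F)F)cc2)sc2c1CCN(Cc1ccccc1F)C2` — 26900 nM
Compound 3 `NC(=O)c1c(NC(=O)c2ccc(C(F)(F)F)cc2)sc2c1CCN(Cc1c(Cl)cccc1Cl)C2` — 8530 nM

Of the compounds shown here, three sharing one core have been measured in a functional assay on MKN-74 cells (Homo sapiens) for antiproliferative activity, with a stated time of 24 h; on this read-out lower numbers stand for stronger inhibition and higher numbers for weaker inhibition. Compound 1 holds the second-highest of the three numbers: compound 1 and compound 3 lie within the scatter of each other, while the step of a 2.1-fold higher number from compound 1 to compound 2 (0.32 log units; beyond the scatter) is beyond the scatter. The further step a 3.2-fold lower number from compound 2 to compound 3 (0.50 log units; beyond the scatter) was measured at the ring amine nitrogen.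

Compound 4 `NC(=O)c1c(NC(=O)c2ccccc2Cl)sc2c1CCN(C(=S)Nc1ccccc1F)C2` has not yet been measured in this assay. It differs from compound 1 by a group of 10 heavy atoms (7 carbon, 1 nitrogen, 1 fluorine, 1 sulfur; one six-membered aromatic ring of carbon only) in place of a group of 8 heavy atoms (7 carbon, 1 fluorine; one six-membered aromatic ring of carbon only), on an amine nitrogen in a ring. Going by the values given here, the step from compound 2 to compound 3 concerns the same place but exchanges one benzyl group for another; no measured step exchanges a benzyl group for a thiourea, so the measured steps give no direct guide. The two steps measured so far are both modest, and the expectation is therefore that compound 4 will stay in the same region as compound 1, with a wide range in either direction: the estimated step is a 1.2-fold higher number from compound 1 to compound 4 (0.07 log units; within the scatter), and compound 4 is expected at 15000 nM (range 5000 nM to 45000 nM).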

Compound 4, half-maximal inhibitory concentration: 12600 nM
For compound 4 the middle estimate is 1.2-fold (0.08 log units) above the measured one; measured number inside the range.
By their numbers in this assay, from the lowest: compounds 3, 4 and 1 (each within the scatter of the next); then compound 2.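

In this assay, replacing the 2-fluorobenzyl group on the amine nitrogen in a ring with the thiourea group gives a 1.0-fold lower number from compound 1 to compound 4 (0.01 log units; within the scatter). Going by these compounds alone, the earlier step at this nitrogen exchanged only one benzyl group for another, whereas this pair shows that a group of another kind, carrying a hydrogen-bond donor, a hydrogen-bond acceptor and a double bond outside aromatic rings, leaves the number within the scatter when the 2-chlorophenyl group stays on the carbonyl carbon. Nothing available explains this outcome.

The compounds shown leave open whether the same exchange would hold alongside the 4-(trifluoromethyl)phenyl group of compound 2. They also leave open how a urea with oxygen in place of the sulfur, or a free ring amine bearing only hydrogen, would read at this nitrogen.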